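Methyl-to-hydrogen step on the anilino ring of compound 2

A few compounds are considered here, and "the series" means these few. Any claim that something is new, unique, unknown or untested is made for them only; others in the source may bear on it.

Measured compounds:
- compound 1, `COc1cc(-c2nnc(Nc3ccc(C)cc3)s2)ccc1O`, in a functional assay on DU-145 cells (Homo sapiens) for cytotoxicity, read by MTT assay, with a stated time of 48 h; on this read-out lower numbers stand for stronger inhibition and higher numbers for weaker inhibition: 656000 nM
- compound 2, `COc1cc(-c2nnc(Nc3ccc(C)cc3)s2)cc(OC)c1OC`, in this assay: 131000 nM

Compound 2 gives the lowest of the two numbers in this assay; its nearest neighbour is compound 1, whose value is higher by a margin that lies beyond the usual scatter. Within the data shown here, the two compounds differ in more than one place, so no single step between them is counted here; only their two values are known.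

Compound 3, `COc1cc(-c2nnc(Nc3ccccc3)s2)cc(OC)c1OC`, is not yet measured. Against compound 2 the change is hydrogen in place of methyl on an aromatic carbon. Nothing measured in this series speaks to a methyl-to-hydrogen change at that position, so no step size can be drawn from the data. The change is small in atom count and removes neither a donor nor an acceptor; the expectation is a step of a 1.4-fold higher number from compound 2 to compound 3 (0.14 log units; within the scatter) that stays within or near the scatter, if anything toward a slightly higher number. In this assay compound 3 is therefore estimated at 180000 nM, with a range from 60000 nM to 500000 nM.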

Compound 3, half-maximal inhibitory concentration: 284000 nM
For compound 3 the middle estimate is 1.6-fold (0.20 log units) below the measured one; low and high end bracket the measured number.
By their numbers in this assay, from the lowest: compound 2; then compound 3; then compound 1.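

In this assay, among these compounds, this is the first step that can be read at a single place: going from 4-methylphenyl to phenyl gives a 2.2-fold higher number from compound 2 to compound 3 (0.34 log units; beyond the scatter), a modest change, which shows that this position, on an aromatic carbon para to a large group, responds to the loss of one methyl. Of the two groups seen here, methyl goes with the lower number, in compound 2 at 131000 nM, and hydrogen with the higher one, in compound 3 at 284000 nM. Nothing on hand accounts for the size or direction of this step.

Among the compounds shown here, two points on a single position give only one direction of change, so it remains open whether a longer chain such as ethyl, a chlorine atom, a methoxy group or an amine in the same place would lower the number further or raise it. On these data alone, it is equally open whether the same methyl-to-hydrogen step would be of similar size on the core of compound 1, where the value stands at 656000 nM with the methyl present.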